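This account rests on a few compounds, and the source may have more. Where it says the series, first, only, none or still open, it means among the compounds named here.

The compounds here were tested in an assay for inhibition of Indoleamine 2,3-dioxygenase 1 (Homo sapiens), with stated times of 10 min and 60 min, tested at 100 uM; a lower number here means a weaker effect, a higher number a stronger effect of the compound at the concentration tested. Compound 1 `O=C1NC(=O)c2c(NCc3ccccc3[N+](=O)[O-])cccc21` gives 4%, compound 2 `O=[N+]([O-])c1cccc(CNc2cc(Br)cc3[nH]ncc23)c1` gives 95%, and compound 3 `O=[N+]([O-])c1cccc(CNc2cc(C(F)(F)F)cc3[nH]ncc23)c1` gives 69%. Among these three numbers compound 3 stands second highest: compound 2 is nearest, with a number higher than compound 3 beyond the scatter, and compound 1 is furthest, with a number lower beyond the scatter. Among the measured compounds shown here, the one measured step, a number 26 percentage points lower from compound 2 to compound 3 (beyond the scatter), involved a trifluoromethyl in place of bromo on an aromatic carbon. Compound 4 `O=C(O)c1cccc(CNc2cc(C(F)(F)F)cc3[nH]ncc23)c1` differs from compound 3 in a different place: carboxy in place of nitro on an aromatic carbon. For the measured compounds named here, no measured pair exchanges nitro for carboxy, so the single measured step does not bear on this change, and nothing among the three measured compounds shows what a carboxy group does in this assay. With no direct guide, a loss of inhibition is expected, and the estimated step is a number 34 percentage points lower from compound 3 to compound 4 (beyond the scatter). Compound 4 is therefore expected to give about 35%, within a range from 5% to 75%.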

Compound 4, a percentage reported as inhibition, at one concentration (the size of the read-out at that concentration, not a potency): 17%
For compound 4 the middle estimate is 18 percentage points above the measured one; low and high end bracket the measured number.
By their numbers in this assay, from the lowest: compound 1; then compound 4; then compound 3; then compound 2.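

In this assay the exchange of nitro for carboxy costs a large part of the inhibition (a number 52 percentage points lower from compound 3 to compound 4 (beyond the scatter)), so this position is far from indifferent to the group it carries. Among the compounds shown here, the only earlier step changed bromo to trifluoromethyl elsewhere on the molecule, and this result is the first to show that the group on the six-membered aromatic ring of carbon only also matters. The loss appears even though nitro and carboxy have the same count of heavy atoms, so that count alone does not decide the outcome here. Nothing among the available data explains the loss. Going by these compounds, whether a nitrile, a methyl ester or a primary amide at this position would restore inhibition remains open. So does whether carboxy would cost as much with bromo in place of trifluoromethyl.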